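Trimming the ether substituent in the cathepsin S series

A few compounds are considered here, and "the series" means these few. Any claim that something is new, unique, unknown or untested is made for them only; others in the source may bear on it.

Going by the values given here, compound 2 `CC(NC(=O)c1ccc(OCc2ccccn2)c(C(F)(F)F)c1Cl)C(=O)C(N)=O` gives 4.8 nM in an assay on isolated protein for inhibition of cathepsin S (Homo sapiens), read by fluorescence (on this read-out lower numbers stand for stronger inhibition and higher numbers for weaker inhibition), the lowest of the two numbers so far. Among the compounds with values here, compound 1 `CC(NC(=O)c1cccc(C(F)(F)F)c1Cl)C(=O)C(N)=O` gives 30.9 nM in this assay, and the one measured step, a 6.4-fold lower number from compound 1 to compound 2 (0.81 log units; beyond the scatter), is the only guide available. Compound 3 `CCOc1ccc(C(=O)NC(C)C(=O)C(N)=O)c(Cl)c1C(F)(F)F` differs from compound 2 by methyl in place of pyridin-2-yl on a saturated chain carbon bound to an oxygen on an aromatic ring. The measured step bears on this change directly: it introduced the whole (pyridin-2-yl)methoxy group onto the core of compound 1, and compound 3 removes the pyridin-2-yl while keeping an ether on the same aromatic carbon. Part of that gain is expected to be lost, so a modest rise in the number is expected for compound 3, short of a full return to compound 1. The estimated step is a 2.5-fold higher number from compound 2 to compound 3 (0.40 log units; beyond the scatter). Compound 3 is accordingly expected near 12 nM, with a range from 5 nM to 30 nM.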

Compound 3, half-maximal inhibitory concentration: 11 nM
Compound 3: middle estimate off by 1.1-fold (0.04 log units), on the high side; low and high end bracket the measured number.
By their numbers in this assay, from the lowest: compound 2; then compound 3; then compound 1.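

In this assay, ethoxy in place of hydrogen on the aromatic carbon gives a 2.8-fold lower number from compound 1 to compound 3 (0.45 log units; beyond the scatter), so a small ether alone accounts for part of the gain seen with the larger group. The pyridin-2-yl still contributes beyond that ether: methyl in its place gives a 2.3-fold higher number from compound 2 to compound 3 (0.36 log units; beyond the scatter), and both steps lie beyond the scatter, with neither group's share dominating by a wide margin. Nothing at hand gives a reason for either step.

From the compounds shown here alone, whether the ring nitrogen of pyridin-2-yl matters, or a plain phenyl in its place would read the same, stays open. Going by these compounds, how a longer chain such as propoxy, or an amine carried on the chain, would read in this assay also remains open.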